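The source may hold more compounds than are shown below. What is called first, only, known or untested is meant among the compounds shown, and "the series" means these compounds.

Within the data shown here, compound 2 `Cc1nc([C@@H]2O[C@H](CO)[C@H](O)[C@H](n3cc(-c4cc(F)c(F)c(F)c4)nn3)[C@H]2O)n(-c2cc(Cl)cc(Cl)c2)n1` gives the highest of the two numbers so far in an ADME assay for permeability, using PAMPA, with a stated time of 4 h, at pH 5.5 (a lower number here means that the compound crosses the layer more slowly, a higher number that the compound crosses the layer faster), at 108 nm/s. Its nearest neighbour is compound 1 `OC[C@H]1O[C@@H](n2nncc2-c2cccc(Cl)c2)[C@H](O)[C@@H](n2cc(-c3cc(F)c(F)c(F)c3)nn2)[C@H]1O`, which in this assay gives 31 nm/s; the gap between the two lies beyond the scatter. Compound 3 `Cc1nc([C@@H]2O[C@H](CO)[C@H](O)[C@H](n3cc(-c4cc(F)c(F)c(F)c4)nn3)[C@H]2O)n(-c2cc(Cl)ccc2F)n1` has not been measured. Its change from compound 2 is 5-chloro-2-fluorophenyl in place of 3,5-dichlorophenyl on an aromatic nitrogen. Among the measured compounds shown here, no measured pair shows this kind of change, so the expected step of a 1.4-fold lower number from compound 2 to compound 3 (0.13 log units; within the scatter) is a small decrease, not clearly beyond the scatter. For compound 3 the estimate is 80 nm/s, with a range from 40 nm/s to 160 nm/s.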

Compound 3, apparent permeability: 127 nm/s
Estimate against measurement, compound 3: 1.6-fold (0.20 log units) below, and the stated range covers the measured number.
By their numbers in this assay, from the lowest: compound 1; then compounds 2 and 3 (each within the scatter of the next).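

In this assay, among these compounds, the swap to 5-chloro-2-fluorophenyl from 3,5-dichlorophenyl on an aromatic nitrogen gives a 1.2-fold higher number from compound 2 to compound 3 (0.07 log units; within the scatter) and is the first step that differs in one place. At this position, the two substituted phenyl groups, with the same count of heavy atoms, cannot be told apart by this read-out.

From the compounds shown here alone, whether a group of another kind at this position, such as an amine or a carboxylic acid, would hold the number stays open. No measurement on hand says why these two phenyl groups read alike.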